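A few compounds are considered here, and "the series" means these few. Any claim that something is new, unique, unknown or untested is made for them only; others in the source may bear on it.

- Compound 1 `Cn1cc(-c2ccc(=O)n(CCOc3ccnc4cc(OCCCC(=O)NO)ccc34)n2)cn1` gives 870 nM
- Compound 2 `Cn1cc(-c2ccc(=O)n(CCOc3ccnc4cc(OCCCCC(=O)NO)ccc34)n2)cn1` gives 370 nM
- Compound 3 `Cn1cc(-c2ccc(=O)n(CCOc3ccnc4cc(OCCCCCC(=O)NO)ccc34)n2)cn1` has not yet been measured

Among the compounds with values here, in a functional assay on EBC-1 cells (Homo sapiens) for antiproliferative activity, read by sulforhodamine B assay, with a stated time of 72 h (on this read-out higher numbers stand for weaker inhibition and lower numbers for stronger inhibition), compound 2 at 370 nM holds the lower of the two numbers so far. Compound 3 carries (hydroxycarbamoyl)methyl in place of hydroxycarbamoyl on a saturated chain carbon, four bonds along the chain from an oxygen on an aromatic ring. Within the data shown here, one measured step bears on this: the same exchange, three bonds along the chain, gave a 2.4-fold lower number from compound 1 to compound 2 (0.37 log units; beyond the scatter) and was modest. A single step sets no trend, and the data do not show whether the lowering continues. A similar modest lowering in this assay is therefore expected, though a result within the scatter remains possible. The expected change is a 1.7-fold lower number from compound 2 to compound 3 (0.23 log units; within the scatter) on this estimate. For compound 3 the estimated value is 220 nM within an expected range of 90 nM to 550 nM for repeated measurements.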

Compound 3, half-maximal inhibitory concentration: 460 nM
Beside the measured number, compound 3's estimate is 2.1-fold (0.32 log units) below it, within the range that was stated.
By their numbers in this assay, from the lowest: compounds 2, 3 and 1 (each within the scatter of the next, the first and the last beyond it).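

In this assay, the lowering seen in the step of a 2.4-fold lower number from compound 1 to compound 2 (0.37 log units; beyond the scatter) does not carry on when the same exchange is made four bonds along the chain from the oxygen on the aromatic ring, where the step is a 1.2-fold higher number from compound 2 to compound 3 (0.09 log units; within the scatter) and no separation can be claimed. The longest chain shown is not separated from the shortest either, the step being a 1.9-fold lower number from compound 1 to compound 3 (0.28 log units; within the scatter), so compound 1 and compound 2 remain the only pair lying beyond the scatter. Nothing available here accounts for this flattening.

The compounds shown leave open what a chain longer than that of compound 3 would give in this assay and whether the numbers would then stay level or climb. They also leave open what a carboxylic acid in place of hydroxycarbamoyl would give on any of these chains.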